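Swapping Nitro for Cyano on a Low-Toxicity Scaffold

The source may report more compounds than this note shows. Statements on the series, on what has been measured and on what is new or still open speak of the compounds shown alone.

Of the compounds shown here, three built on one shared core have been tested in an ADME assay on MT4 cells (Homo sapiens) for cytotoxicity, read by MTT assay, with a stated time of 5 days; a lower number here means that less compound is tolerated, a higher number that more compound is tolerated. Compound 1 `COc1cc2nc(Nc3ccc(C#N)cc3)nc(Nc3c(C)cc(/C=C/C#N)cc3C)c2cc1OC` gives 10200 nM in this assay, a measured number. Compound 2 `COc1cc2nc(SCC(=O)Nc3ccc([N+](=O)[O-])cc3)nc(Nc3c(C)cc(/C=C/C#N)cc3C)c2cc1OC` reaches only a limit of this assay, > 219000 nM, so no number is known for it. Compound 3 `COc1cc2nc([S+]([O-])CC(=O)Nc3cccc([N+](=O)[O-])c3)nc(Nc3c(Cl)cc(/C=C/C#N)cc3Cl)c2cc1OC` likewise stands at a limit, >= 83200 nM, not at a measured number. Among the three values, one sits at the limit of > 219000 nM in this assay, at which 1 of the 3 values shown sits, and one at the limit of >= 83200 nM in this assay, at which 1 of the 3 values shown sits, so compound 3 is known only as a limit, and it is not alone in that. No two of the measured compounds differ in just one place, so no single step has been measured and no cause for any difference can be offered.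

Compound 4 `COc1cc2nc([S+]([O-])CC(=O)Nc3cccc(C#N)c3)nc(Nc3c(Cl)cc(/C=C/C#N)cc3Cl)c2cc1OC` has not yet been measured. It differs from compound 3 in one place: cyano in place of nitro on an aromatic carbon. Because compound 3 gives >= 83200 nM, a value staying around that limit is expected for compound 4. The step is expected to be small, a step that the limit leaves unreadable from compound 3 to compound 4, in no clear direction beyond the usual scatter. For compound 4 the estimated value is 90000 nM, with a range from 40000 nM to 220000 nM, and a limit rather than a number is quite likely to be reported again.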

Compound 4, half-maximal cytotoxic concentration: >= 70300 nM
Compound 4 was reported as a limit; the forecaster's own chance of this, stated with the estimate: 65%; the middle value lies beyond the limit too.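

Among the compounds shown here, compound 3 and compound 4 are both known only as limits in this assay, and no step between them can be read, in size or in direction. The compounds shown leave open what the actual tolerated concentrations of compound 3 and compound 4 are, and whether cyano in place of nitro changes them at all.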